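The compounds below may be only part of what the source reports. "The series", "measured", "known", "first", "only" and "open" are said of these compounds alone.

Notes on the series. In an assay on blood for inhibition of Polyunsaturated fatty acid 5-lipoxygenase (Homo sapiens) (a lower number here means a stronger inhibitor, a higher number a weaker inhibitor), compound 1 `NC(=O)N(O)CCC#C[C@@H]1CC[C@@H](CN2CCN([C@H](c3ccccc3)c3ccc(Cl)cc3)CC2)O1` gives 310 nM. Compound 3 `NC(=O)N(O)CCC#C[C@@H]1CC[C@@H](CN2CCN(C(c3ccc(F)cc3)c3ccc(F)cc3)CC2)O1` gives 140 nM in this assay, and compound 2 `CC(C#Cc1ccc(CN2CCN([C@H](c3ccccc3)c3ccc(Cl)cc3)CC2)o1)N(O)C(N)=O` gives 3500 nM. Compound 1 stands second highest of the three numbers: compound 3 lies nearest, with a number lower than that of compound 1 by more than the scatter, and compound 2 lies furthest, with a much higher number.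

Compound 4 `NC(=O)N(O)CCC#C[C@H]1CC[C@H](CN2CCN([C@H](c3ccccc3)c3ccc(Cl)cc3)CC2)O1` is the next case. Relative to compound 1: the two compounds have the same atoms and bonds and differ only in configuration as drawn: 2 of 3 stereo elements differ; a stereocentre at a saturated ring carbon is drawn S in compound 1 and R in compound 4; a stereocentre at a saturated ring carbon is drawn S in compound 1 and R in compound 4. Among the compounds with values here, no measured pair in the set shows this kind of change, so its size is unknown here. A step toward a weaker inhibitor, around or a little beyond the scatter, is expected for the move a 1.9-fold higher number from compound 1 to compound 4 (0.29 log units; within the scatter). Compound 4 is estimated at 600 nM in this assay, with a range from 150 nM to 2500 nM.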

Compound 4, half-maximal inhibitory concentration: 510 nM
Estimate against measurement, compound 4: 1.2-fold (0.07 log units) above; low and high end bracket the measured number.
By their numbers in this assay, from the lowest: compound 3; then compounds 1 and 4 (each within the scatter of the next); then compound 2.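

In this assay, drawing both saturated ring carbons the opposite way gives a 1.6-fold higher number from compound 1 to compound 4 (0.22 log units; within the scatter). Within the data shown here, this is the first measured pair to test configuration at this position, and the two compounds cannot be told apart by this read-out. The pair therefore reads on configuration alone: the fact that compounds 1 and 4 differ only in the configuration as drawn.

The compounds shown leave open how a change at only one of these ring carbons would read. Also open, on these data alone, is whether a methyl group on either ring carbon would be read the same way in this assay.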